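Single drawn enantiomer of compound 2: permeability outlook

The compounds below may be only part of what the source reports. "The series", "measured", "known", "first", "only" and "open" are said of these compounds alone.

Two compounds of the series have numbers in an ADME assay on Caco-2 cells (Homo sapiens) for permeability, in the apical to basolateral direction; a lower number here means that the compound crosses the layer more slowly, a higher number that the compound crosses the layer faster. Compound 1 `Cn1cc(-c2nc3c(-c4ccc(CNC(=O)c5cc6c(s5)CCCC6)c(F)c4)ccnc3[nH]2)cn1` gives 0.6 10^-6 cm/s in this assay. Compound 2 `Cn1cc(-c2nc3c(-c4ccc5c(c4)CCCC5NC(=O)c4nc(C(C)(C)C)no4)ccnc3[nH]2)cn1` gives 1 10^-6 cm/s in this assay; this is the higher of the two numbers, but the gap to compound 1 lies within the scatter, so the two stand together rather than in an order. Compound 3 `Cn1cc(-c2nc3c(-c4ccc5c(c4)CCC[C@@H]5NC(=O)c4nc(C(C)(C)C)no4)ccnc3[nH]2)cn1` is the next compound for this assay. It differs from compound 2 only in this: the two compounds have the same atoms and bonds; at least one stereo element is drawn with a configuration in one of them and without one in the other: 1 of 1 stereo elements differ; a stereocentre at a saturated ring carbon is drawn without a configuration in compound 2 and S in compound 3. Among the measured compounds shown here, no measured pair differs in a single place, so no measured step guides the expectation. With atoms and bonds unchanged, the step from compound 2 to compound 3 is expected to stay within the scatter, in no set direction. Compound 3 is therefore expected to give 1 10^-6 cm/s in this assay, with a range from 0.5 10^-6 cm/s to 2 10^-6 cm/s. This estimate means a step of no change at the digits printed from compound 2 to compound 3 (within the scatter).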

Compound 3, apparent permeability: 5 10^-6 cm/s
Compound 3: the middle estimate sits 5.0-fold (0.70 log units) below what was measured; measured number above the stated range.
By their numbers in this assay, from the lowest: compounds 1 and 2 (each within the scatter of the next); then compound 3.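

In this assay, a change confined to the stereocentre at the saturated ring carbon gives a 5.0-fold higher number from compound 2 to compound 3 (0.70 log units; beyond the scatter), so this position can move the number with no atom or bond altered. Compounds 1 and 2 differ in more than one place and could not give a reading of this stereocentre, whereas this pair isolates it, with the S drawing carrying the higher number. The only difference available to account for the step is the stereochemical drawing: the fact that one of compounds 2 and 3 is drawn with a defined configuration and the other without, at the place where they differ

The compounds shown leave open how the R configuration at this saturated ring carbon would read in this assay, and so whether the two configurations differ from each other. They also leave open whether the number seen with the S configuration would hold once an amine or a carboxylic acid enters the compound.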